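Removing the benzyloxycarbonyl cap from compound 1

A few compounds are considered here, and "the series" means these few. Any claim that something is new, unique, unknown or untested is made for them only; others in the source may bear on it.

Compound 1 `CCCCOC(=O)CNC(=O)[C@H](CSc1ccc([N+](=O)[O-])cc1[N+](=O)[O-])NC(=O)CC[C@H](NC(=O)OCc1ccccc1)C(=O)OCCCC` gives 95.2 uM in a toxicity assay on KB cells (Homo sapiens) for cytotoxicity, read by fluorescence, with a stated time of 3 days (on this read-out lower numbers stand for an effect already at smaller amounts and higher numbers for an effect only at larger amounts of compound), the highest of the three numbers measured. Compound 2 `CCCCOC(=O)CNC(=O)[C@H](CSc1ccc([N+](=O)[O-])cc1[N+](=O)[O-])NC(=O)CC[C@H](NC(=O)C(C)(C)C)C(=O)OCCCC` gives 83.4 uM, and compound 3 `CCCCOC(=O)CNC(=O)[C@H](CSc1ccc([N+](=O)[O-])cc1[N+](=O)[O-])NC(=O)CC[C@H](NC(=O)/C=C/c1ccccc1)C(=O)OCCCC` gives 34.4 uM. Compound 4 `CCCCOC(=O)CNC(=O)[C@H](CSc1ccc([N+](=O)[O-])cc1[N+](=O)[O-])NC(=O)CC[C@H](N)C(=O)OCCCC` differs from compound 1 by hydrogen in place of benzyloxycarbonyl on an amine nitrogen. The steps at this carbonyl carbon were a 1.1-fold lower number from compound 1 to compound 2 (0.06 log units; within the scatter) and a 2.8-fold lower number from compound 1 to compound 3 (0.44 log units; beyond the scatter), so exchanging the cap has moved the number only modestly, if at all. Within the data shown here, no measured step removes the cap altogether, so the expectation for compound 4 rests on that loose analogy: a step of a 1.2-fold higher number from compound 1 to compound 4 (0.06 log units; within the scatter) is expected, with no change beyond the scatter. Compound 4 is therefore estimated at 110 uM, within a range of 50 uM to 250 uM.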

Compound 4, concentration for half-maximal effect: 107 uM
Compound 4: the middle estimate sits 1.0-fold (0.01 log units) above what was measured, and the stated range covers the measured number.
By their numbers in this assay, from the lowest: compound 3; then compounds 2, 1 and 4 (each within the scatter of the next).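

In this assay the cap on this amine nitrogen can be removed altogether without a change beyond the scatter from the benzyloxycarbonyl or (tert-butyl)carbonyl cap, with a 1.1-fold higher number from compound 1 to compound 4 (0.05 log units; within the scatter) and a 1.3-fold higher number from compound 2 to compound 4 (0.11 log units; within the scatter). Of the caps shown, only (2-phenylethenyl)carbonyl stands apart from the free amine, with a 3.1-fold higher number from compound 3 to compound 4 (0.49 log units; beyond the scatter). Nothing available explains this difference. On these data alone, it remains open whether an acetyl group or a methyl group on this nitrogen would stay with the free amine. As far as these compounds go, it also remains open whether a saturated 3-phenylpropanoyl cap would match the (2-phenylethenyl)carbonyl cap.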